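Styryl pyranone series: methoxy addition onto compound 3

A few compounds are considered here, and "the series" means these few. Any claim that something is new, unique, unknown or untested is made for them only; others in the source may bear on it.

Measured so far in a functional assay on NCI-H460 cells (Homo sapiens) for inhibition, read by sulforhodamine B assay, with a stated time of 48 h; on this read-out lower numbers stand for stronger inhibition of growth and higher numbers for weaker inhibition of growth:
Compound 1, `O=C1C=COC(/C=C/c2ccccc2)C1`, gives 82.4 uM.
Compound 2, `COc1ccc(/C=C/C2CC(=O)C=CO2)cc1OC`, gives 89.6 uM.
Compound 3, `O=c1ccoc(/C=C/c2ccccc2)c1`, gives 509 uM.

Compound 3 stands highest of the three numbers in this assay, meaning the weakest growth inhibition of the set. Its nearest neighbour is compound 2, whose number is lower by a gap beyond the scatter; compound 1 lies further still, also beyond the scatter. For the measured compounds named here, compounds 1 and 2 share a core unlike that of compound 3, so no one-place step leads from either to compound 3.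

Compound 4, `COc1ccc(/C=C/c2cc(=O)cco2)cc1`, is not yet measured. It differs from compound 3 by methoxy in place of hydrogen on an aromatic carbon, the methoxy sitting on an aromatic carbon of the six-membered aromatic ring of carbon only, para to a group of 9 heavy atoms. Going by the values given here, the only guide to methoxy substitution here is the pair compound 1 and compound 2, whose values lie within the scatter of each other; that pair is not a one-place step. The expectation for the step from compound 3 to compound 4 in this assay is therefore no change beyond the scatter, a 1.1-fold lower number from compound 3 to compound 4 (0.05 log units; within the scatter). Compound 4 is estimated at 450 uM, within the range 200 uM to 1000 uM.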

Compound 4, concentration for growth inhibition (reported as GI): 606 uM
The estimate for compound 4 lay 1.3-fold (0.13 log units) below the measured number; the measured number falls inside the stated range.
By their numbers in this assay, from the lowest: compounds 1 and 2 (each within the scatter of the next); then compounds 3 and 4 (each within the scatter of the next).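

In this assay, methoxy in place of hydrogen on an aromatic carbon of the six-membered aromatic ring of carbon only, para to a group of 9 heavy atoms, gives a 1.2-fold higher number from compound 3 to compound 4 (0.08 log units; within the scatter). For the compounds shown here, this is the first one-place reading of the methoxy change, and it shows that on the core of compound 3 this position takes the added methoxy with no change in growth inhibition beyond the scatter. No measured property is available to account for this flat step, so the result stands as an observation only.

One step at one position cannot show whether this position is insensitive to substitution in general, and an amine or a carboxylic acid in place of the methoxy would test that more sharply. Going by these compounds alone, also open is whether methoxy behaves the same way at other carbons of the ring, or on the core of compound 1, where no one-place methoxy step is available to read.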